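Fluoro added to the 4-bromophenyl group of compound 3

A few compounds are considered here, and "the series" means these few. Any claim that something is new, unique, unknown or untested is made for them only; others in the source may bear on it.

In a functional assay on HCC827 cells (Homo sapiens) for cytotoxicity, read by MTT assay, with a stated time of 72 h (on this read-out higher numbers stand for weaker inhibition and lower numbers for stronger inhibition), compound 1 `CN1CCN(c2ccc(Nc3ncc4nc(Nc5cccc([N+](=O)[O-])c5)n(C5CCCC5)c4n3)cc2)CC1` gives < 0.01 nM, which is a limit of the assay. Compound 2 `C#Cc1cccc(Nc2nc3cnc(Nc4ccc(N5CCN(C)CC5)cc4)nc3n2C2CCCC2)c1` gives < 0.01 nM, also a limit. Within the data shown here, compound 3 `CN1CCN(c2ccc(Nc3ncc4nc(Nc5ccc(Br)cc5)n(C5CCCC5)c4n3)cc2)CC1` gives 2.2 nM, the only actual number in the set. Compound 4 `CN1CCN(c2ccc(Nc3ncc4nc(Nc5ccc(Br)cc5F)n(C5CCCC5)c4n3)cc2)CC1` differs from it by fluoro in place of hydrogen on an aromatic carbon: 4-bromophenyl becomes 4-bromo-2-fluorophenyl. The nearest measured steps replace this whole aryl group: an at least 220-fold higher number from compound 1 to compound 3 (2.34 log units; beyond the scatter) and an at least 220-fold higher number from compound 2 to compound 3 (2.34 log units; beyond the scatter), both large. Neither tests a fluoro group, so they give no direction and only widen the range. The expected change, a 1.1-fold lower number from compound 3 to compound 4 (0.04 log units; within the scatter), stays within the scatter. The estimate for compound 4 is 2 nM, with an expected range of 0.3 nM to 10 nM.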

Compound 4, half-maximal inhibitory concentration: 2.3 nM
For compound 4 the middle estimate is 1.2-fold (0.06 log units) below the measured one; the measured number falls inside the stated range.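

In this assay, fluoro on this aromatic carbon, ortho to a large group and meta to the bromo group, leaves the number in place: a 1.0-fold higher number from compound 3 to compound 4 (0.02 log units; within the scatter). Adding it does not narrow the gap to the 3-nitrophenyl and 3-ethynylphenyl compounds, an at least 230-fold higher number from compound 1 to compound 4 (2.36 log units; beyond the scatter) and an at least 230-fold higher number from compound 2 to compound 4 (2.36 log units; beyond the scatter). Both steps are bounds rather than sizes, since one end of each stands at a limit: the limit of < 0.01 nM in this assay, at which 2 of the 4 values shown sit.

On these data alone, whether a methoxy group or an amine on this same carbon would also leave the number in place remains open. As far as these compounds go, how far compound 1 and compound 2 lie past that limit also remains open.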